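Inverting the chain stereocentre of compound 3

A few compounds are considered here, and "the series" means these few. Any claim that something is new, unique, unknown or untested is made for them only; others in the source may bear on it.

Values in a functional assay on VCaP cells (Homo sapiens) for antiproliferative activity, read by CCK-8 assay, with a stated time of 6 days; a lower number here means a stronger inhibitor, a higher number a weaker inhibitor:
- Compound 1 `C[C@@H](Cn1ccc(-c2ccc(C#N)c(Cl)c2)n1)NS(=O)(=O)c1cn(C)cn1`: 13600 nM
- Compound 2 `C[C@@H](Cn1ccc(-c2ccc(C#N)c(Cl)c2)n1)Nc1nccc2ccccc12`: 1470 nM
- Compound 3 `C[C@@H](Cn1ccc(-c2ccc(C#N)c(Cl)c2)n1)Nc1ncnc2ccccc12`: 1310 nM

Compound 3 at 1310 nM sits within the scatter of compound 2 at 1470 nM. Compound 1 at 13600 nM carries a number beyond the scatter from compound 3, so compound 3 stands with compound 2 at the low end of the three.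

Compound 4 `C[C@H](Cn1ccc(-c2ccc(C#N)c(Cl)c2)n1)Nc1ncnc2ccccc12` is the next point, and it departs from compound 3 in one respect: the two compounds have the same atoms and bonds and differ only in configuration as drawn: 1 of 1 stereo elements differ; a stereocentre at a saturated chain carbon is drawn S in compound 3 and R in compound 4. All three measured compounds are drawn with the same configuration, so the series offers no direct reading of this change, and any expectation is loosely anchored. A modest move to a higher number in this assay is expected, though a result within the scatter of compound 3 would remain plausible. The expected size is a 1.9-fold higher number from compound 3 to compound 4 (0.28 log units; within the scatter). For compound 4 the estimated value is 2500 nM, with an expected range of 900 nM to 8000 nM.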

Compound 4, half-maximal inhibitory concentration: > 30000 nM
Compound 4: no number, only a limit (the forecaster's own chance of this, stated with the estimate: 5%); at least 12-fold (1.07 log units) between middle value and limit.
By their numbers in this assay, from the lowest: compounds 3 and 2 (each within the scatter of the next); then compound 1. At a limit, above all of these: compound 4.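

In this assay compound 4 gives > 30000 nM, which is a limit of the assay and not a number. The inversion gives an at least 22-fold higher number from compound 3 to compound 4 (1.35 log units; beyond the scatter), a step beyond the scatter whose true size the limit leaves unknown. Compounds 1, 2 and 3 are all drawn with the same configuration, so this pair gives the first reading of the chain stereocentre, and it shows that this position alone can carry a large step in this series: the fact that compounds 3 and 4 differ only in the configuration as drawn

Going by these compounds alone, only one pair reads this change, so it remains open whether inversion gives a similar step with the groups on the nitrogen in compound 1 or compound 2. Also open, on these data alone, is what an ethyl or hydroxymethyl group in place of the methyl at this stereocentre would give.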